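Working notes: the step from compound 3 to compound 4

The source may report more compounds than this note shows. Statements on the series, on what has been measured and on what is new or still open speak of the compounds shown alone.

Measured so far:
Compound 1 `Cc1ccc(S(=O)(=O)Nc2ccc(NS(=O)(=O)c3cc(F)ccc3F)cc2)cc1` in an assay for inhibition of liver carboxylesterase 1 (Homo sapiens), read by spectrophotometry (a lower number here means a stronger inhibitor, a higher number a weaker inhibitor), gives > 100000 nM, a limit of the assay.
Compound 2 `O=S(=O)(Nc1ccc(NS(=O)(=O)c2ccc(Cl)cc2)cc1)c1ccc(F)cc1` in this assay gives > 100000 nM, a limit of the assay.
Compound 3 `Cc1ccc(S(=O)(=O)Nc2ccc(NS(=O)(=O)c3ccc(F)cc3F)cc2)cc1` in this assay gives > 100000 nM, a limit of the assay.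

Compound 3 thus stands at the limit of this assay and not at a number; the two further values shown are limits as well, so no order among the three compounds can be read. The single-place step that the two limits leave unreadable from compound 1 to compound 3 is unreadable, its size hidden by the two limits. Compound 4 `Cc1ccc(S(=O)(=O)Nc2ccc(NS(=O)(=O)c3ccc(Cl)cc3)cc2)cc1` differs from compound 3 by 4-chlorophenyl in place of 2,4-difluorophenyl on a sulfonyl sulfur. Among the compounds with values here, no measured step bears on this change in a readable way; what the series shows is the limit of > 100000 nM in this assay, at which 3 of the 3 values shown sit, so there is nothing to set a size or a direction for this assay beyond the scatter. Compound 4 is therefore expected to remain at or near the same limit, with the step that the limit leaves unreadable from compound 3 to compound 4 being an expectation without a measured anchor. The estimate for compound 4 in this assay is 150000 nM, with a range from 30000 nM to 1000000 nM.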

Compound 4, inhibition constant: > 100000 nM
Compound 4 gave a limit, no number (the forecaster's own chance of this, stated with the estimate: 80%); the middle value lies beyond the limit too.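

No new step can be read between compound 4 and compounds 1, 2 and 3 in this assay, and all of these steps remain unreadable: the limit of > 100000 nM in this assay, at which 4 of the 4 values shown sit.

The compounds shown leave open the size and direction of each change on a sulfonyl sulfur or aromatic carbon, and none of them carries a number.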